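Selenol to methylselenide on the shared core

The source may hold more compounds than are shown below. What is called first, only, known or untested is meant among the compounds shown, and "the series" means these compounds.

Compound 2 `[SeH]c1nc(NCc2ccccc2)c2ccccc2n1` is followed here toward compound 4 `C[Se]c1nc(NCc2ccccc2)c2ccccc2n1`. In a functional assay on MCF7 cells (Homo sapiens) for cytotoxicity, read by MTT assay, with a stated time of 72 h (a lower number here means that less compound is tolerated, a higher number that more compound is tolerated), compound 2 gives only a limit, > 100000 nM. Compound 1 `COc1ccc(CNc2nc([SeH])nc3ccccc23)cc1` gives a limit as well in this assay, > 100000 nM. Compound 3 `CSc1nc(NCc2ccccc2)c2cccnc2n1`, which carries a methylthio group on a different core, likewise gives a limit in this assay, > 100000 nM. For the measured compounds named here, the only step between measured compounds, hydrogen in place of methoxy on an aromatic carbon, is a step that the two limits leave unreadable from compound 1 to compound 2, because the limit of > 100000 nM in this assay, at which 3 of the 3 values shown sit, leaves no number to compare. The change to compound 4 is methyl in place of hydrogen on a selenium. Going by the values given here, no measured step bears on methylation of the selenium, and the methylthio compound 3 sits at the same limit, so no step beyond the scatter is expected in this assay. Compound 4 is expected to give about 100000 nM, within 30000 nM to 300000 nM. The step from compound 2 to compound 4 is thus estimated as a number no higher from compound 2 to compound 4 (the limit leaves the size open), most likely again reported only as a limit.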

Compound 4, concentration lethal to 50% of the cells: > 100000 nM
Compound 4 gave a limit, no number (the forecaster's own chance of this, stated with the estimate: 75%); the middle value lies on the limit itself.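

Compound 2 and compound 4 both give only limits, so no step can be read between them: the limit of > 100000 nM in this assay, at which 4 of the 4 values shown sit.

The compounds shown leave open the size of any step for methyl in place of hydrogen on a selenium, and any numerical value for the series.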